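A few compounds are considered here, and "the series" means these few. Any claim that something is new, unique, unknown or untested is made for them only; others in the source may bear on it.

Among the measured compounds shown here, in a functional assay on MCF7 cells (Homo sapiens) for cytotoxicity, read by MTT assay, with a stated time of 72 h (on this read-out lower numbers stand for stronger inhibition and higher numbers for weaker inhibition), compound 2 (`O=C1C(=C/C=C/c2ccccc2)C(=O)N(c2ccc(Cl)cc2)N1c1ccc(Cl)cc1`) gives 9400 nM, the lower of the two numbers measured so far, against compound 1 (`COc1ccccc1C=C1C(=O)N(c2ccc(Cl)cc2)N(c2ccc(Cl)cc2)C1=O`) at 26300 nM. For the measured compounds named here, the only measured step, a 2.8-fold lower number from compound 1 to compound 2 (0.45 log units; beyond the scatter), is modest. It exchanges 2-methoxyphenyl for 2-phenylethenyl on a double-bonded chain carbon bound to a double-bonded ring carbon. Compound 3 (`O=C1C(=Cc2c[nH]c3ccccc23)C(=O)N(c2ccc(Cl)cc2)N1c1ccc(Cl)cc1`) changes that same place again: 1H-indol-3-yl in place of 2-phenylethenyl on a double-bonded chain carbon bound to a double-bonded ring carbon. Going by the values given here, no measured compound carries 1H-indol-3-yl, so that single step is the only guide to how far this place can move the number. Among the compounds with values here, a shift no larger than that step is therefore expected in this assay, with a slight lean towards a higher number. The estimated step is a 1.5-fold higher number from compound 2 to compound 3 (0.17 log units; within the scatter), which would not be a clear change beyond the scatter. For compound 3 the expected value is 14000 nM, with an estimated range of 4500 nM to 40000 nM.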

Compound 3, half-maximal inhibitory concentration: 34200 nM
Beside the measured number, compound 3's estimate is 2.4-fold (0.39 log units) below it, and the stated range covers the measured number.
By their numbers in this assay, from the lowest: compound 2; then compounds 1 and 3 (each within the scatter of the next).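

In this assay, the new step shows that this place, on a double-bonded chain carbon bound to a double-bonded ring carbon, can also move the number upwards: 1H-indol-3-yl in place of 2-phenylethenyl gives a 3.6-fold higher number from compound 2 to compound 3 (0.56 log units; beyond the scatter). 1H-indol-3-yl in place of 2-methoxyphenyl gives a 1.3-fold higher number from compound 1 to compound 3 (0.11 log units; within the scatter), so these two groups are not told apart here, and of the three compounds only compound 2 stands apart from the other two. Nothing available explains these differences.

The compounds shown leave open whether a chain longer than 2-phenylethenyl, or a phenyl group carrying an amine or a carboxylic acid, would take the number at this place lower than in compound 2. From the compounds shown here alone, it also remains open whether 1-methyl-1H-indol-3-yl would give a number like that of compound 3.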